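This account rests on a few compounds, and the source may have more. Where it says the series, first, only, none or still open, it means among the compounds named here.

Measured so far:
Compound 1 `CCN(CC)S(=O)(=O)c1ccc(S(=O)(=O)N2CCC[C@@H](C(=O)N3CCC(OC)CC3)C2)cc1`: 1420 nM
Compound 2 `CCN(CC)S(=O)(=O)c1ccc(S(=O)(=O)N2CCC[C@@H](C(=O)N3CCC(COC)CC3)C2)cc1`: 1360 nM

In a functional assay on BXPC-3 cells (Homo sapiens) for inhibition, read by MTT assay, with a stated time of 7 days (on this read-out higher numbers stand for weaker inhibition and lower numbers for stronger inhibition), compound 2 gives 1360 nM and compound 1 gives 1420 nM. These two numbers lie within the scatter of each other, so neither compound ranks ahead.

The next compound is compound 3 `CCN(CC)S(=O)(=O)c1ccc(S(=O)(=O)N2CCC[C@@H](C(=O)N[C@H]3CC[C@@H](OC)CC3)C2)cc1`, and the change is (4-methoxycyclohexyl)amino in place of 4-(methoxymethyl)piperidin-1-yl on a carbonyl carbon. The two compounds have the same atoms, joined differently: the ring on the carbonyl carbon becomes one of carbon only, and the amide hydrogen appears.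

Among the measured compounds shown here, only one measured step bears on this: a 1.0-fold lower number from compound 1 to compound 2 (0.02 log units; within the scatter). That step alters just a group on a saturated ring carbon, whereas the new change replaces the whole group on the carbonyl carbon, so it offers only a loose guide. For the measured compounds named here, no measured compound has a ring of carbon only or an amide hydrogen, so the data give no direction. The expectation is therefore no step beyond the scatter in this assay, held with real uncertainty. The expected change is a 1.1-fold higher number from compound 2 to compound 3 (0.04 log units; within the scatter). For compound 3 the estimated value is 1500 nM, with an expected range from 450 nM to 5000 nM.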

Compound 3, half-maximal inhibitory concentration: 2150 nM
Estimate against measurement, compound 3: 1.4-fold (0.16 log units) below; the measured number falls inside the stated range.
By their numbers in this assay, from the lowest: compounds 2, 1 and 3 (each within the scatter of the next).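

Compound 3 is the only compound shown with a ring of carbon only on the amide and with the amide hydrogen, so it tests this position more broadly than the small change between compound 1 and compound 2. In this assay, (4-methoxycyclohexyl)amino in place of 4-(methoxymethyl)piperidin-1-yl gives a 1.6-fold higher number from compound 2 to compound 3 (0.20 log units; within the scatter) and, in place of 4-methoxypiperidin-1-yl, gives a 1.5-fold higher number from compound 1 to compound 3 (0.18 log units; within the scatter) so the group on the carbonyl carbon can be rebuilt in this way without a step beyond the scatter, and the ring change and the amide hydrogen, which arrive together, cannot be told apart here. Nothing given here accounts for these numbers or says how either feature acts on the cells.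

The three compounds leave open whether the position stays this tolerant of change when the group on the saturated ring carbon is something other than an ether, such as a carboxylic acid or an amine. They also leave open what a plain cyclohexylamino group, carrying no methoxy at all, or the other stereoisomer of the 4-methoxycyclohexyl group would do on the same core.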